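Benzoyl ring swapped for a trimethoxy-bearing ring

This account rests on a few compounds, and the source may have more. Where it says the series, first, only, none or still open, it means among the compounds named here.

Compound 1 `N#CC1=C(N)N(c2ccc(S(N)(=O)=O)cc2)C2=C(C(=O)CCC2)C1c1ccc(Cl)cc1Cl` carries a free amine; in a functional assay on Ehrlich cells (Mus musculus) for cytotoxicity, read by trypan blue exclusion, with a stated time of 2 h, tested at 50 ug/mL (on this read-out lower numbers stand for a weaker effect and higher numbers for a stronger effect at the one concentration tested), compound 1 gives 65%. Compound 2 `N#CC1=C(NC(=O)c2ccccc2)N(c2ccc(S(N)(=O)=O)cc2)C2=C(C(=O)CCC2)C1c1ccc(Cl)cc1Cl`, the benzoyl amide, gives 70% in this assay, the highest of the three numbers; still, a number 5 percentage points higher from compound 1 to compound 2 (within the scatter). Compound 3 `N#CC1=C(NC(=O)c2ccc([N+](=O)[O-])cc2)N(c2ccc(S(N)(=O)=O)cc2)C2=C(C(=O)CCC2)C1c1ccc(Cl)cc1Cl` gives 50% in this assay, and a number 20 percentage points lower from compound 2 to compound 3 (beyond the scatter). Compound 4 `COc1cc(C(=O)NC2=C(C#N)C(c3ccc(Cl)cc3Cl)C3=C(CCCC3=O)N2c2ccc(S(N)(=O)=O)cc2)cc(OC)c1OC` differs from compound 2 by 3,4,5-trimethoxyphenyl in place of phenyl on a carbonyl carbon. Among the compounds with values here, the only measured step that also alters this aromatic ring is the one where a number 20 percentage points lower from compound 2 to compound 3 (beyond the scatter), so a fall of similar, modest size is expected for compound 4 rather than a rise. Compound 4 is therefore estimated to give 55% in this assay, within 40% to 70%. That expectation means a number 15 percentage points lower from compound 2 to compound 4 (beyond the scatter).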

Compound 4, a percentage reported as activity, at one concentration (the size of the read-out at that concentration, not a potency): 95%
For compound 4 the middle estimate is 40 percentage points below the measured one, and the stated range ends below it.
By their numbers in this assay, from the lowest: compound 3; then compounds 1 and 2 (each within the scatter of the next); then compound 4.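

With a number 25 percentage points higher from compound 2 to compound 4 (beyond the scatter) in this assay, this place on the carbonyl carbon proves able to give a rise as well as the fall seen earlier. The further step a number 45 percentage points higher from compound 3 to compound 4 (beyond the scatter) shows how widely the number can move when only the ring on this carbonyl changes. Nothing shown explains why the 3,4,5-trimethoxyphenyl ring has this effect. Still open, from the compounds shown here alone, is whether all of its methoxy groups are needed, and whether a single methoxy group or an amine on the same ring would give a similar number.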